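The compounds below may be only part of what the source reports. "The series", "measured", "known", "first", "only" and "open" are said of these compounds alone.

Measured compounds:
compound 1, `Fc1ccc(CNc2nc(-c3ccccc3C(F)(F)F)nc3ccccc23)cc1`, 3400 nM
compound 2, `FC(F)(F)c1ccccc1-c1nc(NCc2ccc(-c3ccccc3)cc2)c2ccccc2n1`, 3700 nM

In an assay on a protein complex for inhibition of ubiquitin carboxyl-terminal hydrolase 1/WD repeat-containing protein 48 (Homo sapiens), read by fluorescence (on this read-out higher numbers stand for weaker inhibition and lower numbers for stronger inhibition), compound 1 gives 3400 nM and compound 2 gives 3700 nM. Compound 2 sits at one end of these two numbers, but the step of a 1.1-fold higher number from compound 1 to compound 2 (0.04 log units; within the scatter) lies within the scatter, so the two compounds cannot be told apart on this read-out.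

Compound 3, `FC(F)(F)c1ccccc1-c1nc(NCc2ccc(-c3ccc(Cl)cc3)cc2)c2ccccc2n1`, differs from compound 2 by chloro in place of hydrogen on an aromatic carbon, the new atom sitting on an aromatic carbon of a six-membered aromatic ring of carbon only, para to a large group. Among the compounds with values here, no measured step touches this change directly; the only step known, from fluoro to phenyl, was within the scatter. On that basis no shift beyond the scatter is expected, and the step from compound 2 to compound 3 is estimated as a 1.2-fold lower number from compound 2 to compound 3 (0.06 log units; within the scatter). Compound 3 is therefore expected to give about 3200 nM, with a likely range from 1300 nM to 8000 nM.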

Compound 3, half-maximal inhibitory concentration: 3600 nM
Beside the measured number, compound 3's estimate is 1.1-fold (0.05 log units) below it; low and high end bracket the measured number.
By their numbers in this assay, from the lowest: compounds 1, 3 and 2 (each within the scatter of the next).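

In this assay, chloro in place of hydrogen, para to a large group, gives a 1.0-fold lower number from compound 2 to compound 3 (0.01 log units; within the scatter) and so produces no shift that can be read. The larger exchange of fluoro for 4-chlorophenyl gives a 1.1-fold higher number from compound 1 to compound 3 (0.02 log units; within the scatter) and also stays within the scatter, so fluoro, phenyl and 4-chlorophenyl cannot be told apart in this series on this read-out. No evidence is available to explain this flat result.

From the compounds shown here alone, it remains open whether a group of a different kind in this place, such as an amine or a carboxylic acid, would move the number beyond the scatter. Going by these compounds, it is also open whether the number responds to a change elsewhere on the shared core, such as a nitrile in place of trifluoromethyl.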